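Methyl in Place of Fluoro: What to Expect for Compound 3

The source may report more compounds than this note shows. Statements on the series, on what has been measured and on what is new or still open speak of the compounds shown alone.

Measured so far:
compound 1, `CC(C)(C)N(NC(=O)c1ccccc1F)C(=O)c1ccccc1Cl`: 51.3 nM in an assay on cells for agonist activity at ecdysone receptor (Bombyx mori), read by a luciferase reporter, with a stated time of 24 h; on this read-out lower numbers stand for an effect already at smaller amounts and higher numbers for an effect only at larger amounts of compound
compound 2, `CC(C)(C)N(NC(=O)c1cccc(F)c1)C(=O)c1ccccc1Cl`: 69.2 nM in this assay

Compound 2 carries the highest of the two numbers, yet the step between them is a 1.3-fold higher number from compound 1 to compound 2 (0.13 log units; within the scatter), so the two cannot be told apart. Compound 3, `Cc1cccc(C(=O)NN(C(=O)c2ccccc2Cl)C(C)(C)C)c1`, differs from compound 2 by methyl in place of fluoro on an aromatic carbon. Going by the values given here, the only measured step, a 1.3-fold higher number from compound 1 to compound 2 (0.13 log units; within the scatter), moves a fluoro to another ring position rather than exchanging it, and it lies within the scatter; nothing measured bears directly on the methyl exchange. The expected step of a 1.0-fold higher number from compound 2 to compound 3 (0.00 log units; within the scatter) in this assay is therefore nothing beyond the scatter. Compound 3 is estimated at 70 nM, within 30 nM to 170 nM.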

Compound 3, half-maximal effective concentration: 603 nM
For compound 3 the middle estimate is 8.6-fold (0.94 log units) below the measured one; measured number outside the range, above it.
By their numbers in this assay, from the lowest: compounds 1 and 2 (each within the scatter of the next); then compound 3.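

In this assay, 3-methylphenyl in place of 3-fluorophenyl gives an 8.7-fold higher number from compound 2 to compound 3 (0.94 log units; beyond the scatter), so this ring position does not treat all small groups alike, even though one heavy atom simply replaces another. The comparison with the 2-fluorophenyl group shows the same direction, with a 12-fold higher number from compound 1 to compound 3 (1.07 log units; beyond the scatter) in the same read-out. Nothing available here explains this difference. Still open, from the compounds shown here alone, is how other groups at this place, such as chloro, methoxy or an amine, would compare with fluoro and methyl.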